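Chloro on the anilide ring of compound 3

The source may hold more compounds than are shown below. What is called first, only, known or untested is meant among the compounds shown, and "the series" means these compounds.

Three compounds of the series have numbers in a functional assay on HeLa cells (Homo sapiens) for inhibition, read by MTT assay, with a stated time of 72 h; on this read-out higher numbers stand for weaker inhibition and lower numbers for stronger inhibition. Compound 1 `Cc1noc(C)c1-c1cnc(N)c(Oc2ccc(C(=O)NC3CC3)cc2)n1` gives 17800 nM. Compound 2 `Cc1noc(C)c1-c1cnc(N)c(Oc2ccc(C(=O)Nc3ccccc3)cc2)n1` gives 10500 nM. Compound 3 `Cn1cc(-c2cnc(N)c(Oc3ccc(C(=O)Nc4ccccc4)cc3)n2)cn1` gives 12300 nM. Among these three numbers compound 3 stands second highest, with compound 2 nearest and compound 1 furthest, and all three lie within the scatter of one another, so no order among them can be read.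

Compound 4 `Cn1cc(-c2cnc(N)c(Oc3ccc(C(=O)Nc4ccc(Cl)cc4)cc3)n2)cn1` differs from compound 3 by chloro in place of hydrogen on an aromatic carbon, placed on an aromatic carbon of a six-membered aromatic ring of carbon only, para to a large group. For the measured compounds named here, no measured step touches a chloro group. The two steps shown, a 1.7-fold lower number from compound 1 to compound 2 (0.23 log units; within the scatter) and a 1.2-fold higher number from compound 2 to compound 3 (0.07 log units; within the scatter), both stayed within the scatter, the first changing the group on the amide nitrogen and the second the heteroaryl on the shared core, and neither gives a lever for the present change. The step from compound 3 to compound 4 is therefore expected to be a 1.2-fold lower number from compound 3 to compound 4 (0.09 log units; within the scatter), with no direction beyond the scatter. For compound 4 in this assay the estimate is 10000 nM, within a range from 4000 nM to 30000 nM.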

Compound 4, half-maximal inhibitory concentration: 3440 nM
For compound 4 the middle estimate is 2.9-fold (0.46 log units) above the measured one, and the stated range ends above it.
By their numbers in this assay, from the lowest: compound 4; then compounds 2, 3 and 1 (each within the scatter of the next).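

In this assay, chloro in place of hydrogen on an aromatic carbon, para to a large group, gives a 3.6-fold lower number from compound 3 to compound 4 (0.55 log units; beyond the scatter), a modest step and the only one in the series shown that lies beyond the scatter. For the compounds shown here, the two earlier steps changed the group on the amide nitrogen and the heteroaryl on the shared core, and neither moved the number beyond the scatter, so the change from phenyl to 4-chlorophenyl is the first to mark a place in these compounds where a single substitution is readable. No measurement shown bears on why this step occurs, and the chloro group's role remains unexplained.

This single step does not show whether the result depends on chloro itself, or whether fluoro, methyl, methoxy, trifluoromethyl, an amine or a carboxylic acid at the same place would give a step of similar size or direction. It also leaves open whether chloro at other carbons of that ring would do the same, and whether the step carries over when 3,5-dimethyl-1,2-oxazol-4-yl replaces 1-methyl-1H-pyrazol-4-yl on the shared core.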